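Sulfonyl pyrazoline series: cyano to trifluoromethoxy swap

A few compounds are considered here, and "the series" means these few. Any claim that something is new, unique, unknown or untested is made for them only; others in the source may bear on it.

Measured so far, all in a functional assay on NCI-H1975 cells (Homo sapiens) for inhibition, read by sulforhodamine B assay, tested at 10 uM; a lower number here means less inhibition, a higher number more inhibition at the concentration tested (going by the name of the read-out):

- compound 1, `CN1CCN(c2ccc(C3=NN(S(=O)(=O)c4ccc(C#N)cc4)C(c4ccc(N(C)C)cc4)C3)cc2)CC1`, gives 100%
- compound 2, `CN1CCN(c2ccc(C3=NN(S(=O)(=O)c4ccc(OC(F)(F)F)cc4)C(c4ccc(N(C)C)cc4)C3)cc2)CC1`, gives 26.5%
- compound 3, `CN(C)c1ccc(C2CC(c3ccc(-n4cncn4)cc3)=NN2S(=O)(=O)c2ccc(C#N)cc2)cc1`, gives 22.6%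

Compound 1 and compound 2 differ only by trifluoromethoxy in place of cyano on an aromatic carbon; this change produced a number 73.5 percentage points lower from compound 1 to compound 2 (beyond the scatter). Compound 1 and compound 3 differ in the core by 1H-1,2,4-triazol-1-yl in place of 4-methylpiperazin-1-yl on an aromatic carbon, a change that gave a number 77.4 percentage points lower from compound 1 to compound 3 (beyond the scatter). Compound 2 and compound 3 sit within the scatter of each other, so no order between them is claimed.

Compound 4, `CN(C)c1ccc(C2CC(c3ccc(-n4cncn4)cc3)=NN2S(=O)(=O)c2ccc(OC(F)(F)F)cc2)cc1`, is not yet measured in this assay. It differs from compound 3 by trifluoromethoxy in place of cyano on an aromatic carbon, the same change as from compound 1 to compound 2, at the same place in both pairs.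

Because compound 3 already gives 22.6%, a step as large as a number 73.5 percentage points lower from compound 1 to compound 2 (beyond the scatter) cannot repeat from this starting point; the read-out has little room left below it. For the measured compounds named here, the step from compound 3 to compound 4 is therefore expected to be much smaller, a number 12.6 percentage points lower from compound 3 to compound 4 (beyond the scatter), with a direction that rests only on the single earlier pair. Compound 4 is estimated at 10% in this assay, with an expected range from 0% to 25%. On these data alone, whether a second core behaves like the first for this swap is unknown from these three compounds alone.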

Compound 4, a percentage reported as inhibition, at one concentration (the size of the read-out at that concentration, not a potency): 11.1%
Beside the measured number, compound 4's estimate is 1.1 percentage points below it; the range from low to high includes it.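

In this assay the swap of cyano for trifluoromethoxy keeps its direction on the second core, with a number 11.5 percentage points lower from compound 3 to compound 4 (beyond the scatter), but it does not keep its size: the same change on two cores in this assay, a number 73.5 percentage points lower (beyond the scatter) from compound 1 to compound 2 and a number 11.5 percentage points lower (beyond the scatter) from compound 3 to compound 4, 62 percentage points apart, beyond the scatter of two such steps. The swap of 4-methylpiperazin-1-yl for 1H-1,2,4-triazol-1-yl behaves the same way on the trifluoromethoxy side of the series, with a number 15.4 percentage points lower from compound 2 to compound 4 (beyond the scatter), again in the same direction as before but much smaller: the same change on two cores in this assay, a number 77.4 percentage points lower (beyond the scatter) from compound 1 to compound 3 and a number 15.4 percentage points lower (beyond the scatter) from compound 2 to compound 4, 62 percentage points apart, beyond the scatter of two such steps. So the two changes do not add up as fixed increments across these four compounds, and only the direction carries from one core to the other; with a single tested concentration and just two pairs per change, the data do not separate a true dependence of one place on the other from a read-out that has little room left at its low end, and they give no potencies.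

On these data alone, it remains open whether the large effect of the cyano and 4-methylpiperazin-1-yl combination belongs to those two groups specifically, or would also appear with a chloro or methoxy group on that aromatic carbon. As far as these compounds go, it is equally open whether another amine, such as morpholin-4-yl or piperazin-1-yl, could stand in for 4-methylpiperazin-1-yl.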